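Chain Length at the Ester in Algal Growth Inhibitors

The source may report more compounds than this note shows. Statements on the series, on what has been measured and on what is new or still open speak of the compounds shown alone.

Compound 1 `COC(=O)c1cc(N2C(=O)C3=C(CCCC3)C2=O)c(F)cc1Cl` and compound 2 `CCCCOC(=O)c1cc(N2C(=O)C3=C(CCCC3)C2=O)c(F)cc1Cl` share one core, while compound 3 `CCCCCOC(=O)c1cc(N2C(=O)C3=C(CCCC3)C2=O)ccc1Cl` and compound 4 `CCCCCCCCOC(=O)c1cc(N2C(=O)C3=C(CCCC3)C2=O)ccc1Cl` share another; the difference between the two cores is not broken down here. In a functional assay on the whole organism with Scenedesmus acutus as the target (on this read-out higher numbers stand for weaker inhibition and lower numbers for stronger inhibition), compound 1 gives 110 nM and compound 2 gives 67.6 nM. The change propyl in place of hydrogen on a saturated chain carbon bound to an oxygen next to a carbonyl group made the step of a 1.6-fold lower number from compound 1 to compound 2 (0.21 log units; within the scatter). In this assay compound 3 gives 9330 nM. The change propyl in place of hydrogen on a saturated chain carbon, five bonds along the chain from an oxygen next to a carbonyl group is the same kind of change, but the place differs: in compound 1 the carbon is bound to an oxygen next to a carbonyl group, whereas in compound 3 it sits five bonds along the chain from an oxygen next to a carbonyl group. Resting on the step of a 1.6-fold lower number from compound 1 to compound 2 (0.21 log units; within the scatter), which stayed within the scatter, compound 4 is expected to move only by a 1.3-fold higher number from compound 3 to compound 4 (0.11 log units; within the scatter). Compound 4 is thus estimated at 12000 nM, between 4000 nM and 40000 nM.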

Compound 4, half-maximal inhibitory concentration: > 100000 nM
Compound 4 ended at the assay's limit; the forecaster's own chance of this, stated with the estimate: 15%; at least 8.3-fold (0.92 log units) between middle value and limit.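

Propyl in place of hydrogen on the ester chain gave an at least 10-fold higher number from compound 3 to compound 4 (1.03 log units; beyond the scatter) in this assay, so the change did not act alike on the two cores: the same change on two cores in this assay, a 1.6-fold lower number (0.21 log units; within the scatter) from compound 1 to compound 2 and an at least 10-fold higher number (1.03 log units; beyond the scatter) from compound 3 to compound 4, at least 17-fold (1.24 log units) apart, beyond the scatter of two such steps. The value of compound 4, > 100000 nM, is a limit of the assay and not a number. This does not show that the core alone sets the outcome, since the change also sits at a different place on the chain, and two steps cannot separate the two.

As far as these compounds go, it stays open whether a longer chain, such as octyl, would also raise the number on the core of compound 1. From the compounds shown here alone, it is equally open how a carboxylic acid in place of the ester would fare on either core.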